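The source may report more compounds than this note shows. Statements on the series, on what has been measured and on what is new or still open speak of the compounds shown alone.

Working notes on the series. Compound 3 `CCn1c(=O)c2c(nc(Cc3ccccc3)n2C)n(Cc2ccco2)c1=O` gives 12.9 nM in an assay on HEK293 cells for displacement of a labelled ligand from adenosine receptor A2b (Homo sapiens) (on this read-out lower numbers stand for stronger inhibition and higher numbers for weaker inhibition), and stands at the lowest number of the three compounds measured. Compound 2 `CCn1c(=O)c2[nH]c(Cc3ccccc3)nc2n(Cc2ccco2)c1=O` gives 162 nM and compound 1 `CCSCCn1c(=O)c2[nH]c(Cc3cccs3)nc2n(Cc2ccco2)c1=O` gives 275 nM in this assay. Among the measured compounds shown here, the only single-point step measured is a 13-fold lower number from compound 2 to compound 3 (1.10 log units; beyond the scatter), which concerns the methyl on an aromatic nitrogen and not the aryl group. Compound 4 `CCn1c(=O)c2c(nc(Cc3cccs3)n2C)n(Cc2ccco2)c1=O` has not yet been measured. It differs from compound 3 in one place: thiophen-2-yl in place of phenyl on a saturated chain carbon bound to an aromatic carbon. For the measured compounds named here, no measured step isolates this change. Going by the values given here, compound 1 and compound 2 carry the two aryl groups in question but also differ elsewhere, so their two values show only that a thiophene-bearing compound and a phenyl-bearing compound sit close together in this assay. On that basis the expectation for the present change is a step of no consequence beyond the scatter, a 1.2-fold higher number from compound 3 to compound 4 (0.09 log units; within the scatter). Compound 4 is estimated at 16 nM in this assay, with a range from 6 nM to 45 nM.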

Compound 4, inhibition constant: 7.41 nM
For compound 4 the middle estimate is 2.2-fold (0.33 log units) above the measured one, and the stated range covers the measured number.
By their numbers in this assay, from the lowest: compounds 4 and 3 (each within the scatter of the next); then compounds 2 and 1 (each within the scatter of the next).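

In this assay, the change from phenyl to thiophen-2-yl on a saturated chain carbon bound to an aromatic carbon can now be read directly, as a 1.7-fold lower number from compound 3 to compound 4 (0.24 log units; within the scatter) with nothing else altered, whereas compound 1 and compound 2 also differ elsewhere. With the methyl on the aromatic nitrogen held constant, this position therefore takes a five-membered aromatic ring with one sulfur in place of a six-membered carbon ring without a step beyond the scatter. Nothing available explains why the two aryl groups read alike.

From the compounds shown here alone, whether the same change reads alike with hydrogen in place of that methyl remains open. Also open, going by these compounds, is how thiophen-3-yl, an amine, a carboxylic acid or a longer chain would read at this position.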